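A few compounds are considered here, and "the series" means these few. Any claim that something is new, unique, unknown or untested is made for them only; others in the source may bear on it.

Compound 3 `O=C1CSC(c2ccc(F)cc2)N1CCN1CCCCC1` stands level with compound 1 `O=C1CSC(c2cccc(O)c2)N1CCN1CCCCC1` in an ADME assay on Vero cells (Chlorocebus sabaeus) for cytotoxicity, read by neutral red uptake, tested at 3150 ug/mL (a lower number here means a stronger effect, a higher number a weaker effect of the compound at the concentration tested), where compound 3 gives 11% and compound 1 gives 11%; compound 2 `Cc1ccc(C2SCC(=O)N2CCN2CCCCC2)cc1` gives 12%. Going from compound 1 to compound 3 the change was no change at the digits printed from compound 1 to compound 3 (within the scatter), and from compound 2 to compound 3 it was a number 1 percentage points lower from compound 2 to compound 3 (within the scatter). Compound 4 `O=C1CSC(c2ccccc2Cl)N1CCN1CCCCC1` differs from compound 3 by 2-chlorophenyl in place of 4-fluorophenyl on a saturated ring carbon. The two steps that swap the aryl group, a number 1 percentage points higher from compound 1 to compound 2 (within the scatter) and no change at the digits printed from compound 1 to compound 3 (within the scatter), both stayed within the scatter, so no step beyond the scatter is expected from this swap either. Compound 4 is therefore estimated at 12%, with a range from 5% to 22%, which means an expected step of a number 1 percentage points higher from compound 3 to compound 4 (within the scatter).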

Compound 4, a percentage reported as activity, at one concentration (the size of the read-out at that concentration, not a potency): 22%
Compound 4: middle estimate off by 10 percentage points, on the low side; the range from low to high includes it.
By their numbers in this assay, from the lowest: compounds 1, 3, 2 and 4 (each within the scatter of the next, the first and the last beyond it).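

In this assay, for the compounds shown here, swapping the aryl group on the saturated ring carbon now gives steps beyond the scatter (a number 11 percentage points higher from compound 3 to compound 4 (beyond the scatter)) and (a number 11 percentage points higher from compound 1 to compound 4 (beyond the scatter)), which no step among the earlier compounds did. The third step (a number 10 percentage points higher from compound 2 to compound 4 (within the scatter)) stays within the scatter, so compound 4 separates from only two of the three earlier compounds, and only modestly. Nothing available explains these steps. Compound 4 differs from compound 3 in both the halogen and where it sits on the phenyl ring, and the compounds shown do not separate the two. Going by these compounds, how an amine or a carboxylic acid on that phenyl ring would read also remains open.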